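A few compounds are considered here, and "the series" means these few. Any claim that something is new, unique, unknown or untested is made for them only; others in the source may bear on it.

Working notes on the series

Compound 1 `c1cncc(-c2ccccc2OCC2=NCCN2)c1` is the reference point. Among the measured compounds shown here, in a functional assay for activation of Alpha-1D adrenergic receptor (Homo sapiens), read by calcium flux (a higher number here means that more compound is needed for the effect, a lower number that less compound is needed), compound 1 gives 158 nM, the highest of the two numbers measured so far. For the measured compounds named here, its only measured neighbour is compound 2 `c1ccc(-c2ccsc2)c(OCC2=NCCN2)c1`, which in this assay gives 12.6 nM; the change between them is thiophen-3-yl in place of pyridin-3-yl on an aromatic carbon, and the step was a 13-fold lower number from compound 1 to compound 2 (1.10 log units; beyond the scatter).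

Compound 3 `c1ccc(-c2ccns2)c(OCC2=NCCN2)c1` has not yet been measured in this assay. It differs from compound 1 as follows: 1,2-thiazol-5-yl in place of pyridin-3-yl on an aromatic carbon. Going by the values given here, the one measured step that bears on this is the one from compound 1 to compound 2, where a five-membered sulfur-containing ring replaced the pyridin-3-yl group and the number fell by a large margin. The 1,2-thiazol-5-yl group again brings a five-membered ring with sulfur, but it also keeps a ring nitrogen, so the closest analogy is partial. A step downward beyond the scatter is expected, probably somewhat smaller than the step to compound 2, that is a 4.0-fold lower number from compound 1 to compound 3 (0.60 log units; beyond the scatter). The expected value for compound 3 in this assay is therefore 40 nM, with a range from 12 nM to 130 nM.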

Compound 3, half-maximal effective concentration: 25.1 nM
Compound 3: the middle estimate sits 1.6-fold (0.20 log units) above what was measured; low and high end bracket the measured number.
By their numbers in this assay, from the lowest: compounds 2 and 3 (each within the scatter of the next); then compound 1.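

In this assay, the place on an aromatic carbon ortho to a group of 7 heavy atoms now has a second five-membered aromatic ring in place of pyridin-3-yl, and 1,2-thiazol-5-yl gives a 6.3-fold lower number from compound 1 to compound 3 (0.80 log units; beyond the scatter), so the fall is no longer tied to thiophen-3-yl alone. A ring nitrogen as such does not hold the number at the level of compound 1, since 1,2-thiazol-5-yl carries one, and the comparison of the two five-membered rings gives a 2.0-fold higher number from compound 2 to compound 3 (0.30 log units; within the scatter), which leaves them not separated by this read-out. No supporting data on the origin of these steps are available for this series.

Compounds 2 and 3 both bring sulfur and a five-membered ring together, so the compounds shown do not separate ring size from the presence of sulfur; furan-3-yl would have the smaller ring without sulfur, and phenyl would have the six-membered ring without nitrogen. Also open, going by these compounds, is how far the place tolerates something other than an aromatic ring, such as a methoxy group or an amine.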